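Closest Measured Neighbour Guides a Methylbenzyl Amide

This account rests on a few compounds, and the source may have more. Where it says the series, first, only, none or still open, it means among the compounds named here.

Four compounds share one core and differ only in the amide group on its carbonyl carbon. Compound 1 `CC(C)c1c(C(=O)N(C)Cc2ccccc2)nn(-c2ccc(F)cc2)c1OC[C@@H](O)C[C@@H](O)CC(=O)O` was tested in a functional assay on L6 cells (Rattus norvegicus) for inhibition (a higher number here means a weaker inhibitor, a lower number a stronger inhibitor), and gave 6720 nM. Compound 2 `CC(C)c1c(C(=O)NCC2CCCCC2)nn(-c2ccc(F)cc2)c1OC[C@@H](O)C[C@@H](O)CC(=O)O` is recorded in this assay as "not determined" (no result reported). Compound 3 `COc1ccc(CNC(=O)c2nn(-c3ccc(F)cc3)c(OC[C@@H](O)C[C@@H](O)CC(=O)O)c2C(C)C)cc1` is likewise recorded in this assay as "not determined" (no result reported). Compound 4 `Cc1cccc(CN(C)C(=O)c2nn(-c3ccc(F)cc3)c(OC[C@@H](O)C[C@@H](O)CC(=O)O)c2C(C)C)c1` is the untested partner of compound 2; the change is methyl(3-methylbenzyl)amino in place of (cyclohexylmethyl)amino on a carbonyl carbon. Compound 2 has no number, and the step to compound 4 can be given neither a size nor a direction from that pair. Among the measured compounds, compound 4 stands closest to compound 1, and its result is expected near the value of compound 1, 6720 nM. Compound 4 is estimated at 5500 nM, with a range from 1500 nM to 20000 nM.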

Compound 4, half-maximal inhibitory concentration: 18500 nM
Compound 4: middle estimate off by 3.4-fold (0.53 log units), on the low side; the measured number falls inside the stated range.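

In this assay, a single methyl in place of hydrogen on an aromatic carbon gives a 2.8-fold higher number from compound 1 to compound 4 (0.44 log units; beyond the scatter) and so a modestly weaker inhibitor. This pair shows that the amide group responds even to this small addition on its benzyl ring. No supporting data here give a reason for the shift. Steps involving compound 2 or compound 3 cannot be read. Still open, on these data alone, is whether a chlorine atom or a hydroxyl group in place of that methyl would weaken inhibition in the same way.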